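The compounds below may be only part of what the source reports. "The series", "measured", "known", "first", "only" and "open" are said of these compounds alone.

Working notes on the series. Within the data shown here, in a functional assay on cells (T-cell, Homo sapiens) for inhibition (on this read-out lower numbers stand for stronger inhibition and higher numbers for weaker inhibition), compound 1 `COc1ccc(-c2cnc3nc(N)nc(N4CCN(C(=O)NCc5ccc(F)cc5)CC4)c3n2)cc1OC` gives 37 nM, the lowest of the two numbers so far in this assay. Compound 2 `COc1ccc(-c2cnc3nc(N)nc(NC(C)C)c3n2)cc1OC` gives 600 nM in this assay, a gap beyond the scatter. Compound 3 `CC(C)Oc1nc(N)nc2ncc(-c3ccc(C#N)cc3)nc12` reaches only a limit in this assay, > 10000 nM, so no number stands for it (the limit of > 10000 nM in this assay, at which 1 of the 3 values shown sits). Compound 4 `COc1ccc(-c2cnc3nc(N)nc(N4CCN(C(=O)NCc5ccccc5)CC4)c3n2)cc1OC` has not yet been measured in this assay. It differs from compound 1 as follows: hydrogen in place of fluoro on an aromatic carbon. Among the measured compounds shown here, no pair of measured compounds differing in one place is available, so the size of the step is unsupported; with fluoro giving way to hydrogen, a change of none beyond the scatter is expected, if anything a slight weakening. The step from compound 1 to compound 4 in this assay is estimated at a 1.5-fold higher number from compound 1 to compound 4 (0.17 log units; within the scatter). For compound 4 a value of 55 nM is expected, between 20 nM and 150 nM.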

Compound 4, half-maximal inhibitory concentration: 18 nM
Compound 4: the middle estimate sits 3.1-fold (0.49 log units) above what was measured, and the stated range ends above it.
By their numbers in this assay, from the lowest: compound 4; then compound 1; then compound 2. At a limit, above all of these: compound 3.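

Removing the fluoro is tolerated: in this assay hydrogen in place of fluoro on the aromatic carbon gives a 2.1-fold lower number from compound 1 to compound 4 (0.31 log units; beyond the scatter), a modest step that lies beyond the scatter. Among these compounds, this is the first step that changes one place only, and it shows that the 4-fluorobenzyl group is not required, since benzyl serves at least as well here. Nothing at hand accounts for the direction of this step. Going by these compounds, whether a chloro group, a carboxylic acid or an amine at that place on the benzyl group would give a lower or higher number remains open.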